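Thiourea sulfonamides: allyl to ethyl on the thiourea nitrogen

A few compounds are considered here, and "the series" means these few. Any claim that something is new, unique, unknown or untested is made for them only; others in the source may bear on it.

Measured so far:
compound 1, `Cc1cc(C(=O)O)nn1-c1ccc(S(=O)(=O)NC(=S)NC2CCCCC2)cc1` — 1%
compound 2, `C=CCNC(=S)NS(=O)(=O)c1ccc(-n2nc(C(=O)O)cc2C)cc1` — -6%
not yet measured: compound 3, `CCNC(=S)NS(=O)(=O)c1ccc(-n2nc(C(=O)O)cc2C)cc1`

Both measured compounds share the same core; they differ only in the group on the thiourea nitrogen. In a functional assay on the whole organism (blood, strain albino) with Mus musculus as the target, with stated times of 6 days and 4 h, at a dose of 0.4 mmol/kg by the oral route (a higher number here means more inhibition at the dose given (going by the name of the read-out), a lower number less inhibition), compound 1 gives 1%, and compound 2 gives -6%. The one step between them, a number 7 percentage points lower from compound 1 to compound 2 (within the scatter), is within the scatter, so on the numbers shown compound 2 cannot be told apart from compound 1: both read as essentially no inhibition at the dose given.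

Compound 3 follows from compound 2 by methyl in place of vinyl on a saturated chain carbon bound to an amide-type nitrogen, that is, allyl to ethyl. Within the data shown here, the only measured step that bears on this position is a number 7 percentage points lower from compound 1 to compound 2 (within the scatter), where a much larger exchange of the group on this nitrogen left the read-out within the scatter. A smaller change at the same place gives no reason to expect anything else; the step of a number 3 percentage points higher from compound 2 to compound 3 (within the scatter) is therefore expected to stay within the scatter, with no direction beyond it. Compound 3 is expected to give about -3% in this assay, in the range -15% to 10%.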

Compound 3, a percentage reported as inhibition, in the whole organism at one dose (the size of the read-out at that dose, not a potency): -2%
The estimate for compound 3 lay 1 percentage points below the measured number; the measured number falls inside the stated range.
By their numbers in this assay, from the lowest: compounds 2, 3 and 1 (each within the scatter of the next).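

In this assay compound 3 gives -2%, and the step of a number 4 percentage points higher from compound 2 to compound 3 (within the scatter) shows that exchanging the vinyl end of the allyl group for methyl, which removes the only double bond outside the aromatic rings in this substituent, leaves the read-out within the scatter. The step of a number 3 percentage points lower from compound 1 to compound 3 (within the scatter) adds a second comparison at the same nitrogen, ethyl in place of cyclohexyl, so cyclohexyl, allyl and ethyl cannot be told apart here, and all three compounds read as essentially no inhibition at the dose given. No measurement available here explains this flat result or shows whether these compounds reach the blood at useful levels.

Still open, as far as these compounds go, is whether any group on this nitrogen can lift the read-out clear of the scatter, for example a phenyl ring, a longer chain or a chain ending in an amine. Also open, from the compounds shown here alone, is whether an ethyl ester in place of the carboxylic acid on the shared core would change the picture for this set of thiourea substituents.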